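The source may report more compounds than this note shows. Statements on the series, on what has been measured and on what is new or still open speak of the compounds shown alone.

Compound 1 `COc1cc2ncnc(Nc3cccc(Cl)c3)c2cc1OCCCCC(=O)Nc1ccc(S(N)(=O)=O)cc1` gives 33200 nM in a functional assay on NCI-H1975 cells (Homo sapiens) for antiproliferative activity, read by MTT assay, with a stated time of 72 h; a higher number here means a weaker inhibitor, a lower number a stronger inhibitor. Compound 2 `COc1cc2ncnc(Nc3ccc(OCc4cccc(F)c4)c(Cl)c3)c2cc1OCCCCC(=O)Nc1ccc(S(N)(=O)=O)cc1` gives 5670 nM in this assay. Compound 3 `NS(=O)(=O)c1ccc(NC(=S)Nc2ccc3ncnc(Nc4cccc(Cl)c4)c3c2)cc1` gives 39800 nM in this assay.

Compound 2 differs from compound 1 in one place, ((3-fluorobenzyl)oxy in place of hydrogen on an aromatic carbon), and this change gave a 5.9-fold lower number from compound 1 to compound 2 (0.77 log units; beyond the scatter). Compound 3 carries a different core from compound 1; the difference between the two cores is not broken down here. Among the three measured compounds, compound 3 and compound 1 lie within the scatter of each other, while compound 2 sits clearly apart from both.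

Compound 4 `NS(=O)(=O)c1ccc(NC(=S)Nc2ccc3ncnc(Nc4ccc(OCc5cccc(F)c5)c(Cl)c4)c3c2)cc1` has not yet been measured in this assay. It stands to compound 3 as compound 2 stands to compound 1: the change is (3-fluorobenzyl)oxy in place of hydrogen on an aromatic carbon, the same change, made at the same kind of place. Within the data shown here, since the earlier step gave a 5.9-fold lower number from compound 1 to compound 2 (0.77 log units; beyond the scatter), a step of about the same size is expected from compound 3 to compound 4, a 5.9-fold lower number from compound 3 to compound 4 (0.77 log units; beyond the scatter), though with only one prior example the size is uncertain. Compound 4 is therefore estimated at 6800 nM, with a range from 2500 nM to 18000 nM.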

Compound 4, half-maximal inhibitory concentration: 10300 nM
The estimate for compound 4 lay 1.5-fold (0.18 log units) below the measured number; measured number inside the range.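

In this assay the (3-fluorobenzyl)oxy group, set in place of hydrogen on an aromatic carbon, again lowered the number on the second core, giving a 3.9-fold lower number from compound 3 to compound 4 (0.59 log units; beyond the scatter). Set beside the earlier step, the new one points the same way and cannot be told apart from it in size: the same change on two cores in this assay, a 5.9-fold lower number (0.77 log units; beyond the scatter) from compound 1 to compound 2 and a 3.9-fold lower number (0.59 log units; beyond the scatter) from compound 3 to compound 4, 1.5-fold (0.18 log units) apart, within the scatter of two such steps. Among these compounds, in this series the change therefore carried from one core to the other with its effect preserved, but this rests on only two pairs of compounds and does not show that it would carry to any further core, nor does it explain why the group lowers the number.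

The compounds shown leave open whether a plain benzyloxy group without the fluorine, or an amine on a short chain at the same place, would give a step of similar size. They also leave open whether the step would persist if a carboxylic acid stood where the sulfonamide stands, or if another group replaced the chloro group.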